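The source may report more compounds than this note shows. Statements on the series, on what has been measured and on what is new or still open speak of the compounds shown alone.

Compound 1 `CCCCCCCCCCCOc1ccccc1CCC(=O)OC[C@H]1OCC=C[C@H]1OP(=O)(O)OC[C@H](N)C(=O)O` — 12.4%
Compound 2 `N[C@@H](COP(=O)(O)O[C@H]1C=CCO[C@@H]1COC(=O)CCc1ccccc1OCc1cccc(Oc2ccccc2)c1)C(=O)O` — 11.5%

Both numbers come from an assay on HEK293-A cells for agonist activity at putative P2Y purinoceptor 10 (Mus musculus), with a stated time of 1.5 h; a lower number here means a smaller maximal response, a higher number a larger maximal response. In this assay compound 1 gives 12.4% and compound 2 gives 11.5%. The gap between the two lies within the usual scatter of repeated measurements, so the two compounds cannot be told apart on these numbers, and both reach only a small maximal response.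

Compound 3 `N[C@@H](COP(=O)(O)O[C@@H]1C=CCO[C@@H]1COC(=O)CCc1ccccc1OCc1cccc(Oc2ccccc2)c1)C(=O)O` has not been measured yet. It differs from compound 2 only in one respect: the two compounds have the same atoms and bonds; at least one stereo element is drawn with a configuration in one of them and without one in the other: 1 of 4 stereo elements differ; a stereocentre at a saturated ring carbon is drawn S in compound 2 and R in compound 3. Among the measured compounds shown here, no pair of measured compounds that differ in a single place is known here, so the size of such a step has to be guessed rather than read off. Since every measured compound in this assay sits at a small maximal response, the expectation for compound 3 is a step of a number 2.5 percentage points higher from compound 2 to compound 3 (within the scatter), which is a change that may not rise beyond the scatter. Compound 3 is therefore expected to give 14%, with a range from 5% to 35%.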

Compound 3, largest response reached (Emax), in percent of the reference or control that the assay uses: "not active" (no number reported)
Nothing numeric was reported for compound 3; no gap can be computed for the estimate.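

Among the compounds shown here, no step from compound 2 to compound 3 can be read, since compound 3 is reported only as "not active", without a number. The comparison carries one further caveat: the fact that one of compounds 2 and 3 is drawn with a defined configuration and the other without, at the place where they differ. The compounds shown leave open how much the configuration at this saturated ring carbon changes the maximal response in this assay.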